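Trimming the benzylamine arm of compound 1

This account rests on a few compounds, and the source may have more. Where it says the series, first, only, none or still open, it means among the compounds named here.

Compound 1 `COc1ccc(CNCc2c(OC)cc(Oc3cccc(Nc4ccccc4)c3)cc2OC)cc1` gives 6970 nM in a functional assay on SW-620 cells (Homo sapiens) for inhibition, read by MTT assay, with a stated time of 72 h (on this read-out higher numbers stand for weaker inhibition and lower numbers for stronger inhibition), the highest of the two numbers shown; compound 2 `COc1cc(Oc2cccc(Nc3ccccc3)c2)cc(OC)c1CNCc1ccc(F)cc1` gives 6770 nM, with a 1.0-fold lower number from compound 1 to compound 2 (0.01 log units; within the scatter). Compound 3 `CNCc1c(OC)cc(Oc2cccc(Nc3ccccc3)c2)cc1OC` differs from compound 1 by hydrogen in place of 4-methoxyphenyl on a saturated chain carbon bound to an amine nitrogen. Among the compounds with values here, no measured step touches this part of the molecule; the step from compound 1 to compound 2 only shows that changing the 4-methoxyphenyl itself hardly moves the number. Removing it wholesale is a larger change, and a weaker result is expected, a 2.2-fold higher number from compound 1 to compound 3 (0.33 log units; beyond the scatter). Compound 3 is estimated at 15000 nM, between 5000 nM and 50000 nM.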

Compound 3, half-maximal inhibitory concentration: 15000 nM
The estimate for compound 3 equals the measured number at the digits printed, and the stated range covers the measured number.
By their numbers in this assay, from the lowest: compounds 2 and 1 (each within the scatter of the next); then compound 3.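

Where the step from compound 1 to compound 2 showed that the substituent on the aryl ring barely matters, these steps show that the ring itself does count: losing the 4-methoxyphenyl gives a 2.2-fold higher number from compound 1 to compound 3 (0.33 log units; beyond the scatter) and losing the 4-fluorophenyl gives a 2.2-fold higher number from compound 2 to compound 3 (0.35 log units; beyond the scatter) on the same saturated chain carbon. Both steps are modest, so compound 3 keeps a measurable number without any aryl ring on this arm. Nothing at hand explains the loss. Going by these compounds, whether a cyclohexyl ring or a longer chain could stand in for the aryl ring remains open, as does the role of the amine nitrogen itself.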